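From ethoxy to isopropylamino on a shared core

A few compounds are considered here, and "the series" means these few. Any claim that something is new, unique, unknown or untested is made for them only; others in the source may bear on it.

For the measured compounds named here, in a functional assay on CCRF-CEM cells (Homo sapiens) (a lower number here means a stronger inhibitor, a higher number a weaker inhibitor), compound 1 `CCOc1ncnc2c1ncn2C[C@@H]1C[C@H](CO)c2ccccc21` gives 24 ug/mL as its reading, the highest and so the weakest of the three numbers measured so far. Compound 2 `Cn1ncc2c1[C@H](Cn1cnc3c(Cl)nc(N)nc31)C[C@@H]2CO` reads 3.2 ug/mL and compound 3 `Cn1ncc2c1[C@H](Cn1cnc3c(Cl)ncnc31)C[C@@H]2CO[Si](c1ccccc1)(c1ccccc1)C(C)(C)C` reads 3.2 ug/mL on the same scale, but neither differs from compound 1 in just one place. Compound 4 `CC(C)Nc1ncnc2c1ncn2C[C@@H]1C[C@H](CO)c2ccccc21` keeps the core of compound 1 and carries isopropylamino in place of ethoxy on an aromatic carbon and has no reading yet. Going by the values given here, no measured pair shows what this swap does in this assay so the expectation stays close to compound 1 at 24 ug/mL on this scale. The expected step of a 1.2-fold lower number from compound 1 to compound 4 (0.08 log units; within the scatter) is small and stays within the usual scatter. Compound 4 is estimated at 20 ug/mL with 6 ug/mL to 60 ug/mL as the likely range.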

Compound 4, half-maximal inhibitory concentration: 24 ug/mL
Estimate against measurement, compound 4: 1.2-fold (0.08 log units) below, within the range that was stated.
By their numbers in this assay, from the lowest: compounds 2 and 3 (each within the scatter of the next); then compounds 1 and 4 (each within the scatter of the next).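

In this assay, for the compounds shown here, the swap of ethoxy for isopropylamino on an aromatic carbon gives no change at the digits printed from compound 1 to compound 4 (within the scatter) and so offers the first single-change comparison on the shared core. At this position, next to the ring nitrogen, the two groups cannot be told apart, even though isopropylamino brings a hydrogen-bond donor that ethoxy lacks. Nothing available explains why the two read alike. From the compounds shown here alone, whether a carboxylic acid or a longer amine chain at this position would shift the reading remains open. A single pair also cannot establish a general trend for this position.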